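A few compounds are considered here, and "the series" means these few. Any claim that something is new, unique, unknown or untested is made for them only; others in the source may bear on it.

Of the compounds shown here, three have been measured so far, all built on one shared core. Compound 1 `COc1cc2c(cc1OC)C(CC(=O)Nc1ccccc1)CC2` gives 38.9% in a functional assay on the whole organism (strain Wistar) for inhibition, with Rattus norvegicus as the target, read by paw edema, with a stated time of 6 h, at a dose of 100 mg/kg; a higher number here means more inhibition at the dose given (going by the name of the read-out), a lower number less inhibition. Compound 2 `COc1cc2c(cc1OC)C(CC(=O)Nc1cccc(Cl)c1)CC2` gives 38.9% in this assay, and compound 3 `COc1cc2c(cc1OC)C(CC(=O)Nc1ccc(Cl)cc1)CC2` gives 61.1% in this assay. Among these three numbers compound 3 stands highest: the step of a number 22.2 percentage points higher from compound 1 to compound 3 (beyond the scatter) and the step of a number 22.2 percentage points higher from compound 2 to compound 3 (beyond the scatter) both lie beyond the usual scatter, while the step of no change at the digits printed from compound 1 to compound 2 (within the scatter) does not.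

Compound 4 `COc1cc2c(cc1OC)C(CC(=O)Nc1ccc(Br)cc1)CC2` is not yet measured. Its difference from compound 3 is bromo in place of chloro on an aromatic carbon. For the measured compounds named here, no measured step swaps one halogen for another; the two steps that come closest, a number 22.2 percentage points higher from compound 1 to compound 3 (beyond the scatter) and a number 22.2 percentage points higher from compound 2 to compound 3 (beyond the scatter), only show that a chloro on the aromatic carbon para to a large group went with a modest rise. On that slim basis, compound 4 is expected to sit close to compound 3, with an expected step of a number 1.1 percentage points lower from compound 3 to compound 4 (within the scatter), which falls within the scatter. The estimate for compound 4 in this assay is 60%, with a range from 45% to 75%.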

Compound 4, a percentage reported as inhibition, in the whole organism at one dose (the size of the read-out at that dose, not a potency): 46.3%
The estimate for compound 4 lay 13.7 percentage points above the measured number; measured number inside the range.
By their numbers in this assay, from the lowest: compounds 1, 2 and 4 (each within the scatter of the next); then compound 3.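

In this assay, for the compounds shown here, the step of a number 14.8 percentage points lower from compound 3 to compound 4 (beyond the scatter) shows that the choice of halogen counts at this place, para to a large group, something the earlier compounds could not show since none swapped one halogen for another. The gain that came with chloro therefore does not simply carry over to bromo, as the steps of a number 7.4 percentage points higher from compound 1 to compound 4 (within the scatter) and a number 7.4 percentage points higher from compound 2 to compound 4 (within the scatter) both stay within the scatter, leaving the 4-bromophenyl group indistinguishable here from the plain phenyl and the 3-chlorophenyl groups. No measurement at hand explains why these two halogens part at this position.

With only two halogens at this place, the compounds shown leave open how a fluoro, a methyl or an amine there would compare with chloro. Also open, as far as these compounds go, is whether the gap between chloro and bromo would persist at other doses or times, as each number comes from a single dose and time.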